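Compound 3: (3,4-dichlorophenyl)sulfanyl in place of (4-fluorobenzyl)amino

The compounds below may be only part of what the source reports. "The series", "measured", "known", "first", "only" and "open" are said of these compounds alone.

In a functional assay on NCI-H522 cells (Homo sapiens) for inhibition, read by sulforhodamine B assay, with a stated time of 48 h (on this read-out lower numbers stand for stronger inhibition of growth and higher numbers for weaker inhibition of growth), compound 1 `COc1ccc(CNc2nc3cc(N)cc(N)c3nc2-c2ccccc2)cc1OC` gives 2690 nM. Compound 2 `Nc1cc(N)c2nc(-c3ccccc3)c(NCc3ccc(F)cc3)nc2c1` is known in this assay only as a limit, < 100000 nM. Among the measured compounds shown here, the step that the limit leaves unreadable from compound 1 to compound 2 therefore cannot be sized, and the limit of < 100000 nM in this assay, at which 1 of the 2 values shown sits, is the only information bearing on it. Compound 3 `Nc1cc(N)c2nc(-c3ccccc3)c(Sc3ccc(Cl)c(Cl)c3)nc2c1` is reached from compound 2 by (3,4-dichlorophenyl)sulfanyl in place of (4-fluorobenzyl)amino on an aromatic carbon. For the measured compounds named here, no measured step touches either group, so the only anchors are the limit of compound 2 and the number for compound 1. Compound 3 is therefore expected to land broadly near compound 1, with a wide spread on either side. The step that the limit leaves unreadable from compound 2 to compound 3 is an expectation only and has no readable step in this series to be checked against. Compound 3 is estimated at 5000 nM, with a range from 500 nM to 50000 nM.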

Compound 3, concentration for 50% growth inhibition: 7590 nM
For compound 3 the middle estimate is 1.5-fold (0.18 log units) below the measured one; the range from low to high includes it.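

No step can be read from compound 2 to compound 3 in this assay, because the value of compound 2 is a limit: the limit of < 100000 nM in this assay, at which 1 of the 3 values shown sits.

The compounds shown leave open how far (3,4-dichlorophenyl)sulfanyl and (4-fluorobenzyl)amino differ on the shared core in this assay.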